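Swapping a Halogenated Aryl Group on a Urea-Linked Scaffold

A few compounds are considered here, and "the series" means these few. Any claim that something is new, unique, unknown or untested is made for them only; others in the source may bear on it.

Three diaryl ureas built on a shared core have been tested in a functional assay on MDA-MB-231 cells (Homo sapiens) for inhibition, read by MTT assay and WST assay, with a stated time of 72 h, tested at 10 uM; a lower number here means less inhibition of growth, a higher number more inhibition of growth at the concentration tested. Compound 1 `O=C(Nc1ccc(Oc2ccc(-c3nccs3)cc2)cc1)Nc1cc(C(F)(F)F)ccc1Cl` gives 60.4% in this assay. Compound 2 `O=C(Nc1ccc(Oc2ccc(-c3nccs3)cc2)cc1)Nc1cc(Br)cc(C(F)(F)F)c1` differs from it in one place, (3-bromo-5-(trifluoromethyl)phenyl in place of 2-chloro-5-(trifluoromethyl)phenyl on an amide-type nitrogen), and gives 72.8% in this assay; the step of a number 12.4 percentage points higher from compound 1 to compound 2 (beyond the scatter) is a modest gain. Compound 3 `O=C(Nc1ccc(Oc2ccc(-c3ncc[nH]3)cc2)cc1)Nc1cc(C(F)(F)F)ccc1Cl` keeps the aryl group of compound 1 but changes the five-membered ring at the far end of the core, (1H-imidazol-2-yl in place of 1,3-thiazol-2-yl on an aromatic carbon). In this assay compound 3 gives 32.3%. The step of a number 28.1 percentage points lower from compound 1 to compound 3 (beyond the scatter) is the largest single change seen here, and compound 3 stands lowest of the three measured compounds.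

Compound 4 `O=C(Nc1ccc(Oc2ccc(-c3ncc[nH]3)cc2)cc1)Nc1cc(Br)cc(C(F)(F)F)c1` has not yet been measured. It differs from compound 3 in the same way that compound 2 differs from compound 1: 3-bromo-5-(trifluoromethyl)phenyl in place of 2-chloro-5-(trifluoromethyl)phenyl on an amide-type nitrogen. The place of the change is described identically in both pairs, so this is the same change, made once on the core with the thiazole ring and once on the core with the imidazole ring; how those two cores differ is given by 1H-imidazol-2-yl in place of 1,3-thiazol-2-yl on an aromatic carbon. For the measured compounds named here, the step from compound 3 to compound 4 is expected to be about as large as the earlier one, a number 11.7 percentage points higher from compound 3 to compound 4 (beyond the scatter), resting on the single comparison a number 12.4 percentage points higher from compound 1 to compound 2 (beyond the scatter), with only one example to go on. On that basis compound 4 is estimated at 44%, likely between 28% and 60%.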

Compound 4, percent growth inhibition at one concentration: -13.6%
Estimate against measurement, compound 4: 57.6 percentage points above; measured number outside the range, below it.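

The same swap of aryl groups does not carry over between these two cores in this assay. On the core with the imidazole ring it gives a number 45.9 percentage points lower from compound 3 to compound 4 (beyond the scatter), while on the core with the thiazole ring it moved the number the opposite way: the same change on two cores in this assay, a number 12.4 percentage points higher (beyond the scatter) from compound 1 to compound 2 and a number 45.9 percentage points lower (beyond the scatter) from compound 3 to compound 4, 58.3 percentage points apart, beyond the scatter of two such steps

Read from the other side, the swap of the five-membered ring also depends on the aryl group present, with a number 86.4 percentage points lower from compound 2 to compound 4 (beyond the scatter) set against the smaller fall seen with the 2-chloro-5-(trifluoromethyl)phenyl group: the same change on two cores in this assay, a number 28.1 percentage points lower (beyond the scatter) from compound 1 to compound 3 and a number 86.4 percentage points lower (beyond the scatter) from compound 2 to compound 4, 58.3 percentage points apart, beyond the scatter of two such steps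

So in these four compounds the two changes do not simply add up, and a step measured on one core was a poor guide to the same step on the other, but this square of compounds does not show why, nor how a third core would respond.

The compounds shown leave open whether the fall on the core with the imidazole ring belongs to the chlorine leaving or to the bromine entering, as the two go together in both pairs. Also open, going by these compounds, is how either core would respond to a phenyl group carrying a nitrile or a methoxy group instead of a halogen.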